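A few compounds are considered here, and "the series" means these few. Any claim that something is new, unique, unknown or untested is made for them only; others in the source may bear on it.

Series notes, step from compound 3 to compound 4. Compound 3 `Cc1cccc(-c2nc(CN3CCC(C(=O)NCCCN4C[C@H](C)C[C@H](C)C4)CC3)c(C)o2)c1` gives 279 10^-6 cm/s in a physicochemical assay for permeability, using PAMPA (a higher number here means that the compound crosses the layer faster, a lower number that the compound crosses the layer more slowly), the lowest of the two numbers in hand; the nearest is compound 2 `Cc1oc(-c2ccccc2Cl)nc1CN1CCC(C(=O)NCCCN2C[C@H](C)C[C@H](C)C2)CC1` at 352 10^-6 cm/s, and the gap a 1.3-fold lower number from compound 2 to compound 3 (0.10 log units; within the scatter) lies within the scatter. For compound 1 `Cc1ccc(C)c(-c2nc(CN3CCC(C(=O)NCCCN4C[C@H](C)C[C@H](C)C4)CC3)c(C)o2)c1` the entry in this assay is "not determined" (no result reported), so no number is in hand for it. Compound 4 `Cc1ccc(-c2nc(CN3CCC(C(=O)NCCCN4C[C@H](C)C[C@H](C)C4)CC3)c(C)o2)c(C)c1` differs from compound 3 by 2,4-dimethylphenyl in place of 3-methylphenyl on an aromatic carbon. For the measured compounds named here, the only step that bears on this change is the swap of one aryl group for another between compound 2 and compound 3, which stayed within the scatter, so no step beyond the scatter is expected here either. Compound 4 is expected to give 260 10^-6 cm/s in this assay, in the range 150 10^-6 cm/s to 450 10^-6 cm/s. The expected step is therefore a 1.1-fold lower number from compound 3 to compound 4 (0.03 log units; within the scatter), within the scatter.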

Compound 4, apparent permeability: 353 10^-6 cm/s
The estimate for compound 4 lay 1.4-fold (0.13 log units) below the measured number, within the range that was stated.
By their numbers in this assay, from the lowest: compounds 3, 2 and 4 (each within the scatter of the next).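

In this assay the change to 2,4-dimethylphenyl from 3-methylphenyl gives a 1.3-fold higher number from compound 3 to compound 4 (0.10 log units; within the scatter) and so stays within the scatter. The comparison with 2-chlorophenyl gives a 1.0-fold higher number from compound 2 to compound 4 (0.00 log units; within the scatter) and also stays within the scatter, so the three aryl groups with numbers at this position cannot be told apart in this assay. No evidence in hand bears on this result.

Still open, as far as these compounds go, is whether a phenyl ring carrying an amine or a carboxylic acid would stay within this range. From the compounds shown here alone, a non-aromatic group such as cyclohexyl at this position also remains open.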